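The source may report more compounds than this note shows. Statements on the series, on what has been measured and on what is new or still open speak of the compounds shown alone.

Compound 1 `O=C(N/N=C/c1ccc(Br)cc1)Nc1ccc(Oc2ccnc3[nH]ccc23)c(F)c1`: in a functional assay on MCF7 cells (Homo sapiens) for antiproliferative activity, read by MTT assay, with a stated time of 72 h (on this read-out lower numbers stand for stronger inhibition and higher numbers for weaker inhibition), compound 1 gives 930 nM.
Compound 2 `COc1ccc(/C=N/NC(=O)Nc2ccc(Oc3ccnc4[nH]ccc34)c(F)c2)c(OC)c1OC`: in this assay compound 2 gives 134 nM.
Compound 3 `O=C(N/N=C/c1ccc(Br)cc1)Nc1ccc(Oc2ccnc3[nH]ccc23)cc1`: in this assay compound 3 gives "not active" (no number reported), with no number.

Compound 3 therefore stands outside the numbers: while compound 1 and compound 2 each have a measured half-maximal inhibitory concentration in this assay, compound 3 has only the word "not active", so no distance between it and either of them can be stated.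

Compound 4 `CN(C)CCCn1cccc1/C=N/NC(=O)Nc1ccc(Oc2ccnc3[nH]ccc23)cc1` differs from compound 3 in one place: 1-(3-(dimethylamino)propyl)-1H-pyrrol-2-yl in place of 4-bromophenyl on a carbon with a double bond to nitrogen. The part that leaves and the part that enters differ in ring size, in the hetero atom of the ring, in the count of heavy atoms and in the count of hydrogen-bond acceptors, as counted above.

Compound 3 has no number, so no step size can be computed for this change, and any measured number for compound 4 would mean a move from "not active" to active. The expectation here is modest: a measurable but weak value, beyond the scatter only in the sense that a number appears at all. Compound 4 is expected to give about 3000 nM, within a range from 600 nM to 15000 nM, with a fair chance that the assay again reports no number.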

Compound 4, half-maximal inhibitory concentration: 9140 nM
Estimate against measurement, compound 4: 3.0-fold (0.48 log units) below, within the range that was stated.
By their numbers in this assay, from the lowest: compound 2; then compound 1; then compound 4.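

In this assay, for the compounds shown here, compound 3 carries only the words "not active", so no step to compound 4 can be read. Nothing measured here offers an explanation for this result. The compounds shown leave open how much the ring and the attached 3-(dimethylamino)propyl chain of compound 4 each contribute to its activity.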